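The source may report more compounds than this note shows. Statements on the series, on what has been measured and on what is new or still open speak of the compounds shown alone.

Measured in a functional assay on SK-OV-3 cells (Homo sapiens) for cytotoxicity, read by MTT assay, with a stated time of 3 days; on this read-out higher numbers stand for weaker inhibition and lower numbers for stronger inhibition:
Compound 1 `N#Cc1c(Nc2ccccc2)nc(SCc2nc3ccccc3[nH]2)nc1-c1ccccc1`: 4.46 nM
Compound 2 `N#Cc1c(NC(N)=O)nc(SCc2nc3ccccc3[nH]2)nc1-c1ccccc1`: 6.75 nM
Compound 3 `N#Cc1c(-c2ccccc2)nc(SCc2nc3ccccc3[nH]2)nc1N1CCNCC1`: 2.63 nM

Compound 3, at 2.63 nM, cannot be separated from compound 1 but does separate from compound 2. The two measured steps into it exchange the whole group on the aromatic carbon: a 1.7-fold lower number from compound 1 to compound 3 (0.23 log units; within the scatter) and a 2.6-fold lower number from compound 2 to compound 3 (0.41 log units; beyond the scatter). Compound 4 `CN1CCN(c2nc(SCc3nc4ccccc4[nH]3)nc(-c3ccccc3)c2C#N)CC1` differs from compound 3 by methyl in place of hydrogen on an amine nitrogen in a ring. Neither step tests this change directly. Both whole-group exchanges were modest at most, so no step beyond the scatter is expected in this assay. The expected step is a 1.1-fold higher number from compound 3 to compound 4 (0.06 log units; within the scatter). Compound 4 is estimated at 3 nM, with an expected range of 1.3 nM to 7 nM.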

Compound 4, half-maximal inhibitory concentration: 1600 nM
Compound 4: the middle estimate sits 530-fold (2.73 log units) below what was measured; measured number outside the range, above it.
By their numbers in this assay, from the lowest: compounds 3, 1 and 2 (each within the scatter of the next, the first and the last beyond it); then compound 4.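

In this assay, the amine nitrogen in the ring of the piperazin-1-yl group proves highly sensitive to substitution: methyl in place of hydrogen there gives a 610-fold higher number from compound 3 to compound 4 (2.78 log units; beyond the scatter). Earlier whole-group exchanges on the aromatic carbon changed the number modestly at most, whereas 4-methylpiperazin-1-yl stands well apart, with a 240-fold higher number from compound 2 to compound 4 (2.37 log units; beyond the scatter) and a 360-fold higher number from compound 1 to compound 4 (2.55 log units; beyond the scatter). Nothing available explains this jump.

Whether it is specific to methyl remains open, since compounds with ethyl or acetyl on this nitrogen are not among those shown. On these data alone, the effect of a morpholin-4-yl group in place of piperazin-1-yl also remains open.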